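Removing the Fluoro Group: From Compound 3 to Compound 4

The compounds below may be only part of what the source reports. "The series", "measured", "known", "first", "only" and "open" are said of these compounds alone.

Three measured compounds share a common core and differ in their end groups: compound 1 `COc1ccc(-c2ccc(-c3ccc(C(=N)N)cc3)s2)cc1`, compound 2 `N=C(N)c1ccc(-c2ccc(-c3cc(Cl)cc(Cl)c3)s2)cc1` and compound 3 `COc1cc(OC)cc(-c2ccc(-c3ccc(C(=N)N)c(F)c3)s2)c1`. In a functional assay on SK-MEL-5 cells (Homo sapiens) for inhibition, read by sulforhodamine B assay, with a stated time of 48 h (a lower number here means a stronger inhibitor of growth, a higher number a weaker inhibitor of growth), compound 1 gives 1390 nM, compound 2 gives 1600 nM and compound 3 gives 956 nM. Compound 3 has the lowest of the three numbers, yet its gaps to compound 1 and to compound 2 both lie within the scatter, so no order among them can be claimed. Compound 4 `COc1cc(OC)cc(-c2ccc(-c3ccc(C(=N)N)cc3)s2)c1`, not yet measured, differs from compound 3 by one change: hydrogen in place of fluoro on an aromatic carbon. Going by the values given here, no measured pair shows a step of this kind. In this assay the expected step is a 1.2-fold higher number from compound 3 to compound 4 (0.06 log units; within the scatter), small and within the scatter in either direction. Compound 4 is expected to give about 1100 nM, between 500 nM and 2500 nM.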

Compound 4, concentration for 50% growth inhibition: 1810 nM
Beside the measured number, compound 4's estimate is 1.6-fold (0.22 log units) below it, within the range that was stated.
By their numbers in this assay, from the lowest: compounds 3, 1, 2 and 4 (each within the scatter of the next).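

In this assay, going by these compounds alone, the pair of compounds gives the first reading of this change, a 1.9-fold higher number from compound 3 to compound 4 (0.28 log units; within the scatter) at this position. Hydrogen in place of fluoro on this aromatic carbon, ortho to a group of 3 heavy atoms, therefore leaves the number within the usual scatter. No available evidence bears on this result.

On these data alone, whether a chloro, methoxy or amino group at this place would give a step beyond the scatter remains open. So does whether fluoro here would give a similar step alongside the end groups of compound 1 and compound 2.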